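Notes on the step from compound 2 to compound 3

The source may report more compounds than this note shows. Statements on the series, on what has been measured and on what is new or still open speak of the compounds shown alone.

Compound 1 `C[Se]/C(=N\C(=O)c1ccco1)NC(=O)c1ccco1` and compound 2 `CS/C(=N\C(=O)c1ccco1)NC(=O)c1ccco1` share one core and differ only at the carbon with a double bond to nitrogen. In a functional assay on HT-29 cells (Homo sapiens) for cytotoxicity, read by MTT assay, with a stated time of 72 h (a higher number here means a weaker inhibitor of growth, a lower number a stronger inhibitor of growth), compound 1 gives > 100000 nM, which is a limit of the assay and not a number. In this assay compound 2 gives > 100000 nM, again a limit rather than a number. The step that the two limits leave unreadable from compound 1 to compound 2 cannot be read in size, because of the limit of > 100000 nM in this assay, at which 2 of the 2 values shown sit. Compound 3 `O=C(/N=C(/NC(=O)c1ccco1)[Se]Cc1ccccc1)c1ccco1` is still to be measured; its change from compound 2 is a group of 8 heavy atoms (7 carbon, 1 selenium; one six-membered aromatic ring of carbon only) in place of a group of 2 heavy atoms (1 carbon, 1 sulfur; no ring), on a carbon with a double bond to nitrogen. Among the measured compounds shown here, the single measured step, from compound 1 to compound 2, sits at the same position but is unreadable in size, so neither direction nor magnitude can be taken from it. Compound 2 itself stands only at the limit in this assay. Compound 3 is therefore expected to stay at or near that limit, with the step of a number no higher from compound 2 to compound 3 (the limit leaves the size open) expected to lie within the scatter. The estimate for compound 3 in this assay is 100000 nM, expected between 30000 nM and 300000 nM, most likely reported once more as a limit.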

Compound 3, concentration for total growth inhibition: 89100 nM
The estimate for compound 3 lay 1.1-fold (0.05 log units) above the measured number, within the range that was stated.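

In this assay, among the compounds shown here, compound 3 gives 89100 nM, the first value at the carbon with a double bond to nitrogen that is a number and not a limit of the assay. The step with the larger selenium-bound group is an at least 1.1-fold lower number from compound 2 to compound 3 (0.05 log units; that floor lies within the scatter), and phenyl in place of hydrogen on a saturated chain carbon bound to a selenium atom gives an at least 1.1-fold lower number from compound 1 to compound 3 (0.05 log units; that floor lies within the scatter). Both are floors rather than sizes, and whether either true gap lies beyond the scatter stays undecided, because compound 1 and compound 2 supply no number to measure from: the limit of > 100000 nM in this assay, at which 2 of the 3 values shown sit.

The step from compound 1 to compound 2 cannot be read, so the compounds shown do not separate the effect of selenium from that of sulfur, and they leave open whether a benzylsulfanyl group at this carbon would read as compound 3 does. Also open, as far as these compounds go, is how the reading would respond to a longer chain on the selenium, or to an amine or a carboxylic acid on the phenyl ring.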